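Para-substituent swap on the distal ring of the anilinomethylphenol series

This account rests on a few compounds, and the source may have more. Where it says the series, first, only, none or still open, it means among the compounds named here.

Compound 1 `Oc1ccccc1CNc1ccc(-c2ccc(Cl)cc2)cc1` is measured in a functional assay on Jurkat cells (Homo sapiens) for activation, with a stated time of 24 h (a lower number here means that less compound is needed, a higher number that more compound is needed for the effect), at 2390 nM. Its closest neighbour is compound 2 `Oc1ccccc1CNc1ccc(-c2cccc(F)c2)cc1`, which in this assay gives 2020 nM; the step of a 1.2-fold lower number from compound 1 to compound 2 (0.07 log units; within the scatter) shows the two compounds lie within the scatter of each other, so no order between them can be read from these numbers. Compound 3 `Oc1cccc(-c2ccc(NCc3ccccc3O)cc2)c1`, carrying a hydroxyphenyl in the same outer position, is reported in this assay as "not active" (no number reported), with no number attached; it is the only entry in the set that returns no value.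

The step of interest leads to compound 4 `CCCc1ccc(-c2ccc(NCc3ccccc3O)cc2)cc1`. The difference is propyl in place of chloro on an aromatic carbon. Among the compounds with values here, the only measured step touching this outer ring is the one from compound 1 to compound 2, and it is within the scatter. Within the data shown here, no measured pair exchanges chloro for propyl, so the size of the new step has no direct precedent; what the data support is that a halogen change at this ring left the number where it was, while the hydroxyphenyl of compound 3 returned no number at all.

For compound 4 the expectation is therefore a step of about a 1.1-fold higher number from compound 1 to compound 4 (0.04 log units; within the scatter), within the scatter, given that the step from compound 1 to compound 2 was a 1.2-fold lower number from compound 1 to compound 2 (0.07 log units; within the scatter). The estimate for compound 4 in this assay is 2600 nM, with a range of 900 nM to 7500 nM.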

Compound 4, half-maximal effective concentration: 2390 nM
Compound 4: middle estimate off by 1.1-fold (0.04 log units), on the high side, within the range that was stated.
By their numbers in this assay, from the lowest: compounds 2, 1 and 4 (each within the scatter of the next).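

In this assay the exchange of chloro for propyl reads as no change at the digits printed from compound 1 to compound 4 (within the scatter), so this place, para to a large group, takes a group of 3 heavy atoms in place of a group of 1 heavy atom with the number remaining within the scatter. The earlier step on this ring, a 1.2-fold lower number from compound 1 to compound 2 (0.07 log units; within the scatter), joined two halogen-bearing compounds only, so the flat reading now extends to an all-carbon chain, while compound 3, at "not active" (no number reported), remains the one entry that goes against it. No measurement in hand bears on why the number stays where it is.

On these data alone, whether a longer chain such as hexyl, an amine or a carboxylic acid on this same carbon would keep the number within the scatter of compound 1 remains open. Also open is whether the missing number of compound 3 goes with the hydroxyl as a group or with its place on the ring, as the compounds shown offer no hydroxyl at the place of the chloro.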